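Quinoline thiosemicarbazones: aryl swap from compound 3 to compound 4

This account rests on a few compounds, and the source may have more. Where it says the series, first, only, none or still open, it means among the compounds named here.

Measured so far:
compound 1 `S=C(N/N=C/c1ccc2ccccc2n1)Nc1cccc(Br)c1` — 70000 nM
compound 2 `Cc1ccc(NC(=S)N/N=C/c2ccc3ccccc3n2)cc1` — 86000 nM
compound 3 `COc1cccc(NC(=S)N/N=C/c2ccc3ccccc3n2)c1` — 74500 nM

In a functional assay on HeLa cells (Homo sapiens) for antiproliferative activity, read by sulforhodamine B assay, with a stated time of 72 h (on this read-out lower numbers stand for stronger inhibition and higher numbers for weaker inhibition), the three numbers sit close together. Compound 3 stands second highest of the three; the step of a 1.1-fold higher number from compound 1 to compound 3 (0.03 log units; within the scatter) and the step of a 1.2-fold lower number from compound 2 to compound 3 (0.06 log units; within the scatter) both fall within the scatter, so no order among compounds 1, 2 and 3 can be read from them.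

Compound 4 `Cc1ccccc1NC(=S)N/N=C/c1ccc2ccccc2n1` is not yet measured. The change is 2-methylphenyl in place of 3-methoxyphenyl on an amide-type nitrogen. Within the data shown here, the steps that bear on it are the earlier swaps of the ring on the amide-type nitrogen: a 1.2-fold higher number from compound 1 to compound 2 (0.09 log units; within the scatter), a 1.2-fold lower number from compound 2 to compound 3 (0.06 log units; within the scatter) and a 1.1-fold higher number from compound 1 to compound 3 (0.03 log units; within the scatter), each within the scatter. Three such exchanges left this assay unchanged, so for compound 4 no step beyond the scatter is expected in either direction. The expected step is a 1.0-fold higher number from compound 3 to compound 4 (0.00 log units; within the scatter). Compound 4 is therefore estimated at 75000 nM, with a range from 37000 nM to 150000 nM.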

Compound 4, half-maximal inhibitory concentration: > 100000 nM
Compound 4: a limit, no number (the forecaster's own chance of this, stated with the estimate: 10%); middle value at least 1.3-fold (0.12 log units) from the limit.
By their numbers in this assay, from the lowest: compounds 1, 3 and 2 (each within the scatter of the next). At a limit, above all of these: compound 4.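

In this assay compound 4 gives > 100000 nM, which is a limit of the assay and not a number. The steps, an at least 1.3-fold higher number from compound 3 to compound 4 (0.12 log units; that floor lies within the scatter), an at least 1.1-fold higher number from compound 2 to compound 4 (0.06 log units; that floor lies within the scatter) and an at least 1.4-fold higher number from compound 1 to compound 4 (0.15 log units; that floor lies within the scatter), therefore give only floors, so 2-methylphenyl on the amide-type nitrogen is not shown to lower inhibition beyond the scatter, and the swaps at this position still show no firm change. What is new is that one ring at this position reaches the limit, which the earlier swaps did not: the limit of > 100000 nM in this assay, at which 1 of the 4 values shown sits.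

From the compounds shown here alone, how far the true value of compound 4 lies from the others stays open. Going by these compounds, it is also open whether any group at this position, such as an amine or a carboxylic acid on the ring, or a longer chain in place of the ring, moves the number beyond the scatter in either direction.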